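A few compounds are considered here, and "the series" means these few. Any claim that something is new, unique, unknown or untested is made for them only; others in the source may bear on it.

Measured so far in an ADME assay on Karpas-1106P cells (Homo sapiens) for cytotoxicity (on this read-out higher numbers stand for an effect only at larger amounts of compound and lower numbers for an effect already at smaller amounts), each value being a limit and not a number:
- Compound 1 `Cc1ccc(S(=O)(=O)N[C@@H](CC(=O)NC(C)(C)C)C(=O)NCCNC(=O)c2ccccc2)cc1` gives > 11100 nM as a limit
- Compound 2 `Cc1ccc(S(=O)(=O)N[C@@H](CC(=O)NC(C)(C)C)C(=O)NCCNC(=O)c2ccccc2F)cc1` gives > 11100 nM as a limit
- Compound 3 `Cc1ccc(S(=O)(=O)N[C@@H](CC(=O)NC(C)(C)C)C(=O)NCCNC(=O)c2cc(Cl)ccc2Cl)cc1` gives > 11100 nM as a limit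

Compound 3 has no exact number of its own, and the whole set is summed up by the limit of > 11100 nM in this assay, at which 3 of the 3 values shown sit, in this read-out.

Compound 4 `Cc1ccc(S(=O)(=O)N[C@@H](CC(=O)NC(C)(C)C)C(=O)NCCNC(=O)c2ccccc2O)cc1` carries 2-hydroxyphenyl in place of 2,5-dichlorophenyl on a carbonyl carbon, a difference that counts as 2-hydroxyphenyl in place of 2,5-dichlorophenyl on a carbonyl carbon here. The measured steps that bear on this change touch the same aromatic group. From a step that the two limits leave unreadable from compound 1 to compound 3 and a step that the two limits leave unreadable from compound 2 to compound 3 no size or direction can be taken, and a step that the two limits leave unreadable from compound 1 to compound 2 adds none.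

Within the data shown here, compound 4 is therefore expected to stay close to compound 3 in this assay with no step beyond the scatter and no direction to name, in line with the limit of > 11100 nM in this assay, at which 3 of the 3 values shown sit, as the only guide. The expected change is a step that the limit leaves unreadable from compound 3 to compound 4 as a rough estimate. For compound 4 the estimated value is 15000 nM with an expected range from 8000 nM to 40000 nM and a limit is the most likely report.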

Compound 4, half-maximal effective concentration: > 11100 nM
Compound 4 gave a limit, no number; the forecaster's own chance of this, stated with the estimate: 85%; the middle value does not contradict the limit.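

Compound 4, like compound 1, compound 2 and compound 3, gives only a limit and no exact number in this assay, so none of the steps among them can be read: the limit of > 11100 nM in this assay, at which 4 of the 4 values shown sit. The compounds shown leave open at what concentration any of them would affect these cells, and whether changing the aromatic group on the carbonyl carbon alters that concentration.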